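Chain-terminal group variation: nitrile to acetyl

A few compounds are considered here, and "the series" means these few. Any claim that something is new, unique, unknown or untested is made for them only; others in the source may bear on it.

Measured so far:
compound 1 `CCCn1c(=O)n(CCC#N)c(=O)c2[nH]cnc21`, 15900 nM
compound 2 `CCCn1c(=O)n(CCCN(C)C)c(=O)c2[nH]cnc21`, 43200 nM

In an assay on Cerebral cortex for binding affinity to adenosine receptor A1 (Cavia porcellus), read by radioligand binding (a higher number here means a weaker inhibitor, a lower number a stronger inhibitor), compound 1 holds the lower of the two numbers; the step of a 2.7-fold higher number from compound 1 to compound 2 (0.43 log units; beyond the scatter) separates it from compound 2. Compound 3 `CCCn1c(=O)n(CCC(C)=O)c(=O)c2[nH]cnc21` is not yet measured. It differs from compound 1 as acetyl in place of cyano on a saturated chain carbon, two bonds along the chain from an aromatic nitrogen. Among the measured compounds shown here, the only measured step that bears on it is a 2.7-fold higher number from compound 1 to compound 2 (0.43 log units; beyond the scatter), at the same chain position but with a different entering group, so the guidance is indirect. A small step, possibly within the scatter and if anything towards a higher number, is expected for compound 3: a 1.3-fold higher number from compound 1 to compound 3 (0.10 log units; within the scatter). Compound 3 is therefore estimated at 20000 nM, between 8000 nM and 50000 nM.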

Compound 3, inhibition constant: 11200 nM
Compound 3: the middle estimate sits 1.8-fold (0.25 log units) above what was measured, within the range that was stated.
By their numbers in this assay, from the lowest: compounds 3 and 1 (each within the scatter of the next); then compound 2.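

Replacing nitrile with acetyl at this position gives a 1.4-fold lower number from compound 1 to compound 3 (0.15 log units; within the scatter) and so leaves the number unresolved from that of compound 1 in this assay for these two groups. The other new comparison, a 3.9-fold lower number from compound 2 to compound 3 (0.59 log units; beyond the scatter) as the step, shows that compound 2 stands apart from the acetyl compound as well as from the nitrile compound. No available measurement bears on the reason for these differences.

On these data alone, whether a carboxylic acid or a primary amide at this position would fall with compounds 1 and 3 remains open. Also open, as far as these compounds go, is whether a primary amine or a longer chain would follow compound 2.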